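A few compounds are considered here, and "the series" means these few. Any claim that something is new, unique, unknown or untested is made for them only; others in the source may bear on it.

The series opens with compound 1 `Cc1ccc(-c2c[nH]nc2S(=O)(=O)CC2=NCCS2)cc1`, which in a functional assay, tested at 100 ug/mL (a lower number here means a weaker effect, a higher number a stronger effect of the compound at the concentration tested), was recorded as "not active" (no number reported). Compound 2 `O=S(=O)(CC1=NCCO1)c1n[nH]cc1-c1ccccc1` in this assay gives 58.5%. Compound 3 `O=S(=O)(CC1=NCCO1)c1n[nH]cc1-c1ccc(Cl)cc1` in this assay is reported as "not active" (no number reported), so no single number stands for compound 3, and compound 1 is the one further entry without a number. Compound 4 `Cc1ccc(-c2c[nH]nc2S(=O)(=O)CC2=NCCO2)cc1` differs from compound 3 by methyl in place of chloro on an aromatic carbon. Going by the values given here, no step between measured compounds covers this change. Since compound 1, carrying the same methyl, gave "not active" (no number reported), a weak outcome again seems likely, and any shift in this assay from compound 3 is expected to remain within the scatter. Compound 4 is expected to give 15% in this assay, with a range from 0% to 45%.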

Compound 4, a percentage reported as activity, at one concentration (the size of the read-out at that concentration, not a potency): 65.5%
Compound 4: middle estimate off by 50.5 percentage points, on the low side; measured number above the stated range.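

Methyl in place of hydrogen on this aromatic carbon, para to a large group, gives a number 7 percentage points higher from compound 2 to compound 4 (within the scatter) in this assay, so methyl and hydrogen here cannot be told apart. Chloro at the same place, in compound 3, is recorded as "not active" (no number reported), yet with the same methyl as compound 4, compound 1 is recorded as "not active" (no number reported), so methyl alone does not fix the outcome. Nothing measured here accounts for these differences. Open, from the compounds shown here alone, is how a methoxy group, a fluoro or an amine at this carbon would read in this assay, and whether the chloro result holds of compound 1.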